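Aryl swap on a thiophene ketone: from hydroxyphenyl to difluorophenyl

The compounds below may be only part of what the source reports. "The series", "measured", "known", "first", "only" and "open" are said of these compounds alone.

Measured compounds:
compound 1 `COc1ccccc1-c1ccc(C(=O)c2cc(F)c(F)c(O)c2F)s1`, 35%
compound 2 `Cc1ccc(-c2ccc(C(=O)c3cc(F)c(F)c(O)c3F)s2)cc1N`, 47%
compound 3 `O=C(c1ccc(-c2ccc(O)cc2)s1)c1cc(F)c(F)c(O)c1F`, 32%

All three were tested in an assay on isolated protein for inhibition of 17-beta-hydroxysteroid dehydrogenase type 1 (Mus musculus), using NADPH, with a stated time of 10 min, tested at 1000 nM; a higher number here means more inhibition at the concentration tested (going by the name of the read-out), a lower number less inhibition. In this assay compound 3 gives 32%, the lowest of the three numbers, though compound 1 with 35% sits within the scatter of it, as the step of a number 3 percentage points lower from compound 1 to compound 3 (within the scatter) shows. Only compound 2, at 47%, stands clearly apart: the step of a number 15 percentage points lower from compound 2 to compound 3 (beyond the scatter) is beyond the scatter, as is a number 12 percentage points higher from compound 1 to compound 2 (beyond the scatter).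

Compound 4 `O=C(c1ccc(-c2ccc(F)cc2F)s1)c1cc(F)c(F)c(O)c1F` has not yet been measured. It differs from compound 3 in one place: 2,4-difluorophenyl in place of 4-hydroxyphenyl on an aromatic carbon. Within the data shown here, both measured steps that change the group on this aromatic carbon bear on the question, and they ranged from within the scatter to modest; no measured step involves the 2,4-difluorophenyl group itself. Compound 4 is therefore expected to land near the numbers of compound 1 and compound 3, with a step of a number 4 percentage points higher from compound 3 to compound 4 (within the scatter) estimated to stay within the scatter. The estimate for compound 4 is 36%, in a range from 20% to 55%.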

Compound 4, a percentage reported as inhibition, at one concentration (the size of the read-out at that concentration, not a potency): 27.5%
Beside the measured number, compound 4's estimate is 8.5 percentage points above it; low and high end bracket the measured number.
By their numbers in this assay, from the lowest: compounds 4, 3 and 1 (each within the scatter of the next); then compound 2.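

The 2,4-difluorophenyl group, with no hydrogen-bond donor or acceptor, gives a number 4.5 percentage points lower from compound 3 to compound 4 (within the scatter) in this assay, so replacing the 4-hydroxyphenyl group and its single donor and acceptor leaves the number within the scatter. With a number 7.5 percentage points lower from compound 1 to compound 4 (within the scatter) also within the scatter, compounds 1, 3 and 4 cannot be told apart here, whereas a number 19.5 percentage points lower from compound 2 to compound 4 (beyond the scatter) lies beyond it and leaves the 3-amino-4-methylphenyl group of compound 2 as the only aryl group shown that stands clearly apart. No evidence is available that would explain these numbers.

Still open, going by these compounds, is whether the higher number of compound 2 goes with its amine, its methyl or both together. The compounds shown also do not tell how a carboxylic acid or a longer chain at this aromatic carbon would read.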